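Methyl for tert-butyl on the saturated ring carbon

This account rests on a few compounds, and the source may have more. Where it says the series, first, only, none or still open, it means among the compounds named here.

Among the measured compounds shown here, compound 1 `CC(C)(C)[C@]1(c2ccccc2)OCC[C@H](CCNCc2ccccc2)O1` is the only member of this small set with a numerical value in an assay on brain for displacement of a labelled ligand from Sigma non-opioid intracellular receptor 1 (Cavia porcellus) (a higher number here means a weaker inhibitor, a lower number a stronger inhibitor), where compound 1 gives 253 nM. Compound 2 `CC(C)(C)[C@@]1(c2ccccc2)OCC[C@@H](CCN)O1` reaches only the limit of the assay, > 10000 nM. Compound 3 `NCC[C@H]1CCO[C@@H](c2ccccc2)O1` likewise stops at the limit, > 10000 nM. For the measured compounds named here, with the limit of > 10000 nM in this assay, at which 2 of the 3 values shown sit, describing both of its neighbours, compound 1 stands alone at a measurable inhibition constant, and no measured pair tells how the group on the saturated ring carbon matters. Compound 4 `C[C@]1(c2ccccc2)OCC[C@H](CCNCc2ccccc2)O1` differs from compound 1 by methyl in place of tert-butyl on a saturated ring carbon. Going by the values given here, with no measured step to lean on, a modest loss is expected, a 2.4-fold higher number from compound 1 to compound 4 (0.38 log units; beyond the scatter), near the edge of the usual scatter. Compound 4 is therefore estimated at 600 nM, between 150 nM and 3000 nM.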

Compound 4, inhibition constant: 11 nM
For compound 4 the middle estimate is 55-fold (1.74 log units) above the measured one; the whole stated range lies above it.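

In this assay methyl in place of tert-butyl gives a 23-fold lower number from compound 1 to compound 4 (1.36 log units; beyond the scatter) and so shows that the group on this saturated ring carbon, between two ring oxygen atoms, strongly affects the inhibition constant. Of this pair, compound 4, with 1 heavy atom at this place rather than 4, is the stronger inhibitor, so tert-butyl is not required here for a measurable value. Among the compounds shown here, the other compounds give no further step to read: the limit of > 10000 nM in this assay, at which 2 of the 4 values shown sit.

From the compounds shown here alone, whether ethyl, isopropyl or plain hydrogen on this carbon would give a lower or higher number remains open.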